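The source may report more compounds than this note shows. Statements on the series, on what has been measured and on what is new or still open speak of the compounds shown alone.

Compound 1 `Nc1ccccc1NC(=O)c1ccc(CSC(=S)N2CCc3cc([N+](=O)[O-])ccc32)cc1` — in a functional assay on A-375 cells (Homo sapiens) for antiproliferative activity, read by CCK-8 assay, with a stated time of 72 h, tested at 2 uM (on this read-out higher numbers stand for a stronger effect at the one concentration tested and lower numbers for a weaker effect), compound 1 gives 16.9%.
Compound 2 `CN(Cc1cccnc1)C(=S)SCc1ccc(C(=O)Nc2ccccc2N)cc1` — in this assay compound 2 gives 39.4%.
Compound 3 `COc1ccc(N2CCN(C(=S)SCc3ccc(C(=O)Nc4ccccc4N)cc3)CC2)cc1` — in this assay compound 3 gives 28.1%.

Compound 3 stands second highest of the three numbers in this assay. Its nearest neighbour is compound 1, whose value lies lower by more than the scatter, and the furthest is compound 2, whose value lies higher by more than the scatter. So compound 3 sits in the middle of the set, separated from both ends.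

Compound 4 `N#Cc1ccc(N2CCN(C(=S)SCc3ccc(C(=O)Nc4ccccc4N)cc3)CC2)cc1` has not yet been measured in this assay. It differs from compound 3 in one place: cyano in place of methoxy on an aromatic carbon. Read one bond further out, a 4-methoxyphenyl becomes a 4-cyanophenyl; the group sits on an aromatic carbon of a six-membered aromatic ring of carbon only, para to a large group. Among the compounds with values here, no measured pair in this set shows the effect of such an exchange, so there is nothing to lean on beyond the value of compound 3 itself.

The step from compound 3 to compound 4 is therefore expected to be small, a number 1.9 percentage points higher from compound 3 to compound 4 (within the scatter), with no clear direction and likely within the scatter. Compound 4 is estimated at 30% in this assay, within a range from 15% to 46%.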

Compound 4, a percentage reported as inhibition, at one concentration (the size of the read-out at that concentration, not a potency): 41.4%
For compound 4 the middle estimate is 11.4 percentage points below the measured one; the measured number falls inside the stated range.
By their numbers in this assay, from the lowest: compound 1; then compound 3; then compounds 2 and 4 (each within the scatter of the next).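

Within the data shown here, this pair is the first in the set that differs in one place, and it shows that the aromatic carbon para to a large group is not indifferent to what it carries: in this assay cyano in place of methoxy gives a number 13.3 percentage points higher from compound 3 to compound 4 (beyond the scatter) on this read-out. The two groups match in heavy-atom count and in hydrogen-bond acceptors, and neither brings a ring or a net charge, so these counts do not separate them, yet the number still moves. No evidence at hand says what lies behind the step.

From the compounds shown here alone, with one exchange at this position, it stays open whether a chlorine, a trifluoromethyl or an amine there would give a similar number. Going by these compounds, it also stays open whether the same exchange would give a like step on a core other than that of compound 3.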